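Chloro Added to the Phenyl of an Inactive Analogue

The compounds below may be only part of what the source reports. "The series", "measured", "known", "first", "only" and "open" are said of these compounds alone.

Compound 1 `Cc1cc(S(=O)(=O)Nc2nc3cscc3c(=O)n2Cc2ccccc2)c(S)cc1Cl` gives 4500 nM in a functional assay on T47D cells (Homo sapiens) for inhibition; a higher number here means a weaker inhibitor of growth, a lower number a stronger inhibitor of growth. Compound 2 `Cc1cc(S(=O)(=O)Nc2nc3cc(-c4ccccc4)sc3c(=O)n2Cc2ccccc2)c(S)cc1Cl` returns only a limit in this assay, namely > 100000 nM, so compound 2 stands at the limit of > 100000 nM in this assay, at which 1 of the 2 values shown sits, rather than at a number. Compound 3 `Cc1cc(S(=O)(=O)Nc2nc3cc(-c4ccc(Cl)cc4)sc3c(=O)n2Cc2ccccc2)c(S)cc1Cl` differs from compound 2 by chloro in place of hydrogen on an aromatic carbon. Going by the values given here, no measured step involves a change of this kind, so the data give no size for it; the step from compound 2 to compound 3 is expected to be none beyond the scatter a step that the limit leaves unreadable from compound 2 to compound 3. Compound 3 is accordingly estimated at 150000 nM, between 30000 nM and 1000000 nM, in this assay, most likely again as a limit.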

Compound 3, concentration for 50% growth inhibition: > 100000 nM
Compound 3: no number, only a limit (the forecaster's own chance of this, stated with the estimate: 75%); the middle value does not contradict the limit.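

Compound 2 and compound 3 both return only a limit, not a number, so no step between them can be read: the limit of > 100000 nM in this assay, at which 2 of the 3 values shown sit.

On these data alone, whether chloro in place of hydrogen on the phenyl changes growth inhibition at all in this assay stays open.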